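A few compounds are considered here, and "the series" means these few. Any claim that something is new, unique, unknown or untested is made for them only; others in the source may bear on it.

Measured compounds in a functional assay on CHO cells for agonist activity at Alpha-1A adrenergic receptor (Homo sapiens), read by FLIPR and calcium flux; a higher number here means that more compound is needed for the effect, a lower number that less compound is needed:
- compound 1 `CCCS(=O)(=O)Nc1cccc2c1CCC2c1ncc[nH]1` gives 1340 nM
- compound 2 `Cn1cc(-c2cccc3c2CCC3c2ncc[nH]2)cn1` gives only a limit of the assay, > 2900 nM
- compound 3 `c1ccc(-c2cccc3c2CCC3c2ncc[nH]2)nc1` gives 1150 nM

Compound 3 holds the lowest of the two numbers available in this assay; its nearest neighbour is compound 1, and the two sit within the scatter of each other (a 1.2-fold lower number from compound 1 to compound 3 (0.07 log units; within the scatter)). Against compound 2 the picture is different: the change of 1-methyl-1H-pyrazol-4-yl into pyridin-2-yl gives an at least 2.5-fold lower number from compound 2 to compound 3 (0.40 log units; beyond the scatter), the only step in the set that lies beyond the scatter, and it rests on the limit (the limit of > 2900 nM in this assay, at which 1 of the 3 values shown sits).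

Compound 4 `c1cc(-c2ccn[nH]2)c2c(c1)C(c1ncc[nH]1)CC2` is not yet measured. It differs from compound 3 by 1H-pyrazol-5-yl in place of pyridin-2-yl on an aromatic carbon.

The step that bears most on this change is an at least 2.5-fold lower number from compound 2 to compound 3 (0.40 log units; beyond the scatter), where a five-membered azole at this position gave a higher number than pyridin-2-yl; the step of a 1.2-fold lower number from compound 1 to compound 3 (0.07 log units; within the scatter) shows that a different substituent at the same position can also leave the number unchanged. Compound 4 carries a five-membered azole again, though not the same one as compound 2, so a modest rise in the number is expected, a 1.7-fold higher number from compound 3 to compound 4 (0.24 log units; within the scatter), with a real chance that only a limit is returned. The estimate for compound 4 in this assay is 2000 nM, within a range of 800 nM to 5000 nM.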

Compound 4, half-maximal effective concentration: 52 nM
For compound 4 the middle estimate is 38-fold (1.59 log units) above the measured one, and the stated range ends above it.
By their numbers in this assay, from the lowest: compound 4; then compounds 3 and 1 (each within the scatter of the next). At a limit, above all of these: compound 2.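

In this assay, five-membered azoles at this position do not all behave alike: 1H-pyrazol-5-yl gives a 22-fold lower number from compound 3 to compound 4 (1.34 log units; beyond the scatter), whereas 1-methyl-1H-pyrazol-4-yl had gone the other way against the same pyridin-2-yl, so ring size alone does not set the outcome, with compound 2 the case against any such rule. Among these compounds, the change also separates compound 4 from the sulfonamide, with a 26-fold lower number from compound 1 to compound 4 (1.41 log units; beyond the scatter), and from the other azole, with an at least 55-fold lower number from compound 2 to compound 4 (1.74 log units; beyond the scatter), so this position can move the number far more than the earlier compounds showed. Compound 2 gives only a limit of the assay, so the size of that last step is a lower bound: the limit of > 2900 nM in this assay, at which 1 of the 4 values shown sits.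

Compound 2 differs from compound 4 both in the methyl group and in the point of attachment of the ring, so the compounds shown do not tell which of the two matters. From the compounds shown here alone, the behaviour of 1H-pyrazol-4-yl and 1-methyl-1H-pyrazol-5-yl at this position remains open, and these two groups would pull those features apart.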